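Trimming the Triazole Substituent in an Adenosine Receptor Series

The source may hold more compounds than are shown below. What is called first, only, known or untested is meant among the compounds shown, and "the series" means these compounds.

Measured compounds:
Compound 1, `CNC(=O)[C@@]12C[C@@H]1[C@@H](n1cnc3c(NCc4cccc(Cl)c4)nc(C#CCCCCc4cn(-c5ccc(N)cc5)nn4)nc31)[C@H](O)[C@@H]2O`, 87.1 nM
Compound 2, `C#CCCCC#Cc1nc(NCc2cccc(Cl)c2)c2ncn([C@@H]3[C@H](O)[C@H](O)[C@]4(C(=O)NC)C[C@H]34)c2n1`, 23.6 nM
Compound 3, `CNC(=O)[C@@]12C[C@@H]1[C@@H](n1cnc3c(NCc4cccc(Cl)c4)nc(C#CCCCCc4cn(Cc5ccc(-n6sccc6=O)cc5)nn4)nc31)[C@H](O)[C@@H]2O`, 102 nM

All three compounds share one core and were tested in an assay on CHO cells for displacement of a labelled ligand from adenosine receptor A3 (Homo sapiens), read by scintillation counting; a lower number here means a stronger inhibitor, a higher number a weaker inhibitor. In this assay compound 2 gives 23.6 nM, compound 1 gives 87.1 nM, and compound 3 gives 102 nM. Compound 3 carries the highest number of the three. Its gap to compound 1 lies within the scatter, so the two cannot be told apart; its gap to compound 2 lies beyond the scatter, so compound 2 is the clearly stronger inhibitor of the pair.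

Compound 4, `CNC(=O)[C@@]12C[C@@H]1[C@@H](n1cnc3c(NCc4cccc(Cl)c4)nc(C#CCCCCc4cn(CCNC(C)=O)nn4)nc31)[C@H](O)[C@@H]2O`, is not yet measured. It differs from compound 3 in one place: a group of 5 heavy atoms (3 carbon, 1 nitrogen, 1 oxygen; no ring) in place of a group of 12 heavy atoms (9 carbon, 1 nitrogen, 1 oxygen, 1 sulfur; one five-membered aromatic ring with 2 hetero atoms, one six-membered aromatic ring of carbon only), on a saturated chain carbon bound to an aromatic nitrogen. The two compounds that carry a large group at this position, compound 1 and compound 3, sit close together, while compound 2, which lacks the whole ring-bearing chain end, sits lower. Among the compounds with values here, a smaller group on the chain end might therefore land anywhere between them, and no measured step settles the question. The step of a 1.6-fold lower number from compound 3 to compound 4 (0.20 log units; within the scatter) is expected to be small, at most a modest move to a lower number, and quite possibly within the scatter. Compound 4 is estimated at 65 nM, with a plausible range from 25 nM to 200 nM.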

Compound 4, inhibition constant: 22.3 nM
For compound 4 the middle estimate is 2.9-fold (0.46 log units) above the measured one; the whole stated range lies above it.
By their numbers in this assay, from the lowest: compounds 4 and 2 (each within the scatter of the next); then compounds 1 and 3 (each within the scatter of the next).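

In this assay this position proves sensitive to the group it carries: acetamidomethyl in place of the ring-bearing group of compound 3 gives a 4.6-fold lower number from compound 3 to compound 4 (0.66 log units; beyond the scatter), and 2-acetamidoethyl in place of 4-aminophenyl on an aromatic nitrogen gives a 3.9-fold lower number from compound 1 to compound 4 (0.59 log units; beyond the scatter). Both steps lie beyond the scatter, so the closeness of compound 1 and compound 3 did not mean that all groups here give the same number, and in these two pairs the group without a ring goes with the stronger inhibitor. No measurement shown gives a reason for this.

Going by these compounds, it remains open whether losing the rings or gaining the amide matters more. A plain butyl chain, an amine or a carboxylic acid in place of the acetamide would help separate the two.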